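The source may hold more compounds than are shown below. What is called first, only, known or untested is meant among the compounds shown, and "the series" means these compounds.

Measured in an in vitro ADME assay on microsomes from liver (Homo sapiens) for metabolic stability; on this read-out higher numbers stand for fast clearance and lower numbers for slow clearance
- compound 1 `COCc1nc2nc(C)cc(Nc3ccc(C(F)(F)F)cc3)n2n1` gives 6.7 mL.min-1.g-1
- compound 2 `COCCc1nc2nc(C)cc(Nc3ccc(S(F)(F)(F)(F)F)cc3)n2n1` gives 11.5 mL.min-1.g-1
- compound 3 `CCc1nc2nc(C)cc(Nc3cccc(Cl)c3)n2n1` gives 78.3 mL.min-1.g-1

Compound 2 lies within the scatter of compound 1, and compound 3 stands beyond the scatter with the highest number of the three. Compound 4 `Cc1cc(Nc2ccc(S(F)(F)(F)(F)F)cc2)n2nc(C3CC3)nc2n1` is not yet measured. It carries cyclopropyl in place of 2-methoxyethyl on an aromatic carbon. For the measured compounds named here, no pair of measured compounds differs at this place alone, so the data give no direct guide. The expectation therefore starts from compound 2 at 11.5 mL.min-1.g-1, and no step beyond the scatter is expected in this assay. The expected change is small: a 1.3-fold lower number from compound 2 to compound 4 (0.11 log units; within the scatter). For compound 4 the estimate is 9 mL.min-1.g-1, with an expected range from 3.5 mL.min-1.g-1 to 24 mL.min-1.g-1.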

Compound 4, intrinsic clearance in microsomes: < 5 mL.min-1.g-1
Compound 4: only a limit was reported (the forecaster's own chance of this, stated with the estimate: 5%); middle value at least 1.8-fold (0.25 log units) from the limit.
By their numbers in this assay, from the lowest: compounds 1 and 2 (each within the scatter of the next); then compound 3. At a limit, below all of these: compound 4.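

In this assay, cyclopropyl in place of 2-methoxyethyl on an aromatic carbon between two ring nitrogen atoms gives an at least 2.3-fold lower number from compound 2 to compound 4 (0.36 log units; beyond the scatter). For the compounds shown here, this is the first single-place step, and it shows that this position can move clearance with the rest of compound 2 unchanged. Compound 4 reads < 5 mL.min-1.g-1, which is a limit and not a number, so the full size of the step stays unknown: the limit of < 5 mL.min-1.g-1 in this assay, at which 1 of the 4 values shown sits.

The compounds shown do not separate the gain of the three-membered ring from the loss of the oxygen. From the compounds shown here alone, how an amine or a carboxylic acid at this position would read also remains open.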